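This account rests on a few compounds, and the source may have more. Where it says the series, first, only, none or still open, it means among the compounds named here.

Working notes on the series. In a functional assay on a cell-free system (plasma, Homo sapiens) for inhibition, with Plasma (Rattus norvegicus) as the target (a lower number here means a stronger inhibitor, a higher number a weaker inhibitor), compound 1 `Cc1c(OCc2ccccc2)ccc2c(N3CCNCC3)cc(=O)oc12` gives 1900 nM, compound 2 `COc1c(C)cnc(COc2ccc3c(N4CCNCC4)cc(=O)oc3c2C)c1C` gives 3300 nM, and compound 3 `COCOc1ccc2c(N3CCNCC3)cc(=O)oc2c1C` gives 2300 nM. Compound 1 therefore stands within the scatter of both other compounds, and no order can be read among the three.

Compound 4 `Cc1c(OCc2ccccc2-c2ccccc2)ccc2c(N3CCNCC3)cc(=O)oc12` is the next to be examined. Its change from compound 1 is phenyl in place of hydrogen on an aromatic carbon, which is phenyl in place of hydrogen on an aromatic carbon.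

The measured steps that bear on this all concern the group on a saturated chain carbon bound to an oxygen on an aromatic ring. They are a 1.7-fold higher number from compound 1 to compound 2 (0.24 log units; within the scatter), a 1.2-fold higher number from compound 1 to compound 3 (0.08 log units; within the scatter) and a 1.4-fold lower number from compound 2 to compound 3 (0.16 log units; within the scatter). Replacing phenyl at that place with two quite different groups has so far left the number within the scatter. None of these steps adds phenyl on an aromatic carbon, so they offer only indirect guidance, and the range has to stay wide.

In this assay, no step beyond the scatter is expected, and the estimate is a 1.3-fold higher number from compound 1 to compound 4 (0.12 log units; within the scatter). For compound 4 the expected value is 2500 nM, with an estimated range of 900 nM to 7000 nM.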

Compound 4, half-maximal inhibitory concentration: 17300 nM
Estimate against measurement, compound 4: 6.9-fold (0.84 log units) below; measured number outside the range, above it.
By their numbers in this assay, from the lowest: compounds 1, 3 and 2 (each within the scatter of the next); then compound 4.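

In this assay, phenyl in place of hydrogen on an aromatic carbon, ortho to a large group, gives a 9.1-fold higher number from compound 1 to compound 4 (0.96 log units; beyond the scatter). Among the compounds shown here, this is the first step beyond the scatter: the earlier replacements of the phenyl on the saturated chain carbon left the number within the scatter, whereas this addition to that phenyl ring does not, so the series is not indifferent to every change in this part of the molecule. The added phenyl weakens inhibition here, and no measurement shown explains this step.

Whether a smaller group such as methyl, or a group of another kind such as an amine or a carboxylic acid, on the same aromatic carbon would raise the number as far remains open, so the compounds shown cannot say whether this step belongs to phenyl itself or to any group at that carbon. With a single step at this place, compound 4 against compound 1 marks one point and gives no trend.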